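The source may hold more compounds than are shown below. What is called first, only, known or untested is meant among the compounds shown, and "the series" means these compounds.

Three compounds have been measured:
compound 1, `Cc1[nH]c2ccccc2c1C1CC(c2ccncc2)=NO1`, 21200 nM;
compound 2, `COc1ccc2c(C3CC(c4ccncc4)=NO3)c[nH]c2c1`, 10500 nM;
compound 3, `Cc1c(C2CC(c3ccncc3)=NO2)c2ccccc2n1Cc1ccc(Cl)cc1`, 11200 nM.

All three were tested in a functional assay on PC-3 cells (Homo sapiens) for inhibition, read by MTT assay, with a stated time of 48 h; on this read-out lower numbers stand for stronger inhibition and higher numbers for weaker inhibition. Compound 3 is compound 1 carrying a 4-chlorobenzyl in place of hydrogen on an aromatic nitrogen, the change (4-chlorobenzyl in place of hydrogen on an aromatic nitrogen). That change gave a 1.9-fold lower number from compound 1 to compound 3 (0.28 log units; within the scatter). Compound 2 is built on a different core, and how the core of compound 2 differs from the core of compound 1 is not broken down here. Compound 2 and compound 3 lie within the scatter of each other; compound 2 and compound 1 lie beyond it.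

Compound 4, `COc1ccc2c(C3CC(c4ccncc4)=NO3)cn(Cc3ccc(Cl)cc3)c2c1`, has not yet been measured. It stands to compound 2 as compound 3 stands to compound 1, through the change (4-chlorobenzyl in place of hydrogen on an aromatic nitrogen). The two places are not the same word for word: in compound 1 the aromatic nitrogen is next to the ring atom that bears a methyl group, whereas in compound 2 no such methyl group is there, so this is the same kind of change rather than the same change. In this assay the expected step, a 1.5-fold lower number from compound 2 to compound 4 (0.18 log units; within the scatter), rests on the earlier 1.9-fold lower number from compound 1 to compound 3 (0.28 log units; within the scatter). Compound 4 is therefore estimated to give 7000 nM, likely between 3000 nM and 18000 nM.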

Compound 4, half-maximal inhibitory concentration: 95100 nM
The estimate for compound 4 lay 14-fold (1.13 log units) below the measured number, and the stated range ends below it.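

In this assay, 4-chlorobenzyl in place of hydrogen on an aromatic nitrogen gave a 9.1-fold higher number from compound 2 to compound 4 (0.96 log units; beyond the scatter), which stands for weaker inhibition. Set beside the earlier step, the same change did not behave alike on the two cores, so the result on one core could not be carried over to the other in this series: the same change on two cores in this assay, a 1.9-fold lower number (0.28 log units; within the scatter) from compound 1 to compound 3 and a 9.1-fold higher number (0.96 log units; beyond the scatter) from compound 2 to compound 4, 17-fold (1.23 log units) apart, beyond the scatter of two such steps

This does not show which feature of the cores sets the two results apart, as the difference between them is not broken down into single changes, and two pairs say nothing about how the change would behave on a third core.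

From the compounds shown here alone, it remains open how other groups on that aromatic nitrogen would behave on these two cores, for example a longer chain ending in an amine or a carboxylic acid. Going by these compounds, it also remains open whether either of them would follow the step to compound 3 or the step to compound 4.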